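Chloro in place of diethylamino: expectation for compound 3

A few compounds are considered here, and "the series" means these few. Any claim that something is new, unique, unknown or untested is made for them only; others in the source may bear on it.

Measured so far:
compound 1 `CCN(CC)c1ccc(/C=C/C(=O)c2ccc(OC)c3c2OC(C)(C)C=C3)cc1`: 620 nM
compound 2 `COc1ccc(C(=O)/C=C/c2ccc(N(c3ccccc3)c3ccccc3)cc2)c2c1C=CC(C)(C)O2`: > 10000 nM

Among the compounds with values here, in a functional assay on HCT-116 cells (Homo sapiens) for antiproliferative activity, read by MTT assay, with a stated time of 24 h (a higher number here means a weaker inhibitor, a lower number a stronger inhibitor), compound 1 gives 620 nM, the only number in the set. Compound 2 reports only a limit, > 10000 nM, not a number (the limit of > 10000 nM in this assay, at which 1 of the 2 values shown sits). Compound 3 `COc1ccc(C(=O)/C=C/c2ccc(Cl)cc2)c2c1C=CC(C)(C)O2` carries chloro in place of diethylamino on an aromatic carbon. No measured pair among the compounds shown isolates a change of this kind. The change is expected to weaken the inhibitor beyond the usual scatter, estimated as a 4.8-fold higher number from compound 1 to compound 3 (0.68 log units; beyond the scatter). Compound 3 is estimated at 3000 nM, with a range from 1000 nM to 10000 nM, in this assay.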

Compound 3, half-maximal inhibitory concentration: > 10000 nM
Compound 3: only a limit was reported; the forecaster's own chance of this, stated with the estimate: 30%; at least 3.3-fold (0.52 log units) between middle value and limit.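

In this assay, chloro in place of diethylamino on an aromatic carbon gives an at least 16-fold higher number from compound 1 to compound 3 (1.20 log units; beyond the scatter), the first step read at this position, para to a large group. Compound 3 reports only a limit, > 10000 nM, not a number. Diethylamino is thus the only group at this position with a measured number, and chloro joins the values at the ceiling: the limit of > 10000 nM in this assay, at which 2 of the 3 values shown sit.

Going by these compounds, the true size of the step stays unknown. On these data alone, whether a dimethylamino group or a free amine at this position keeps a measurable number remains open.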